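Exchanging the Amide Substituent in a Small Series

The source may report more compounds than this note shows. Statements on the series, on what has been measured and on what is new or still open speak of the compounds shown alone.

Three compounds were measured in a functional assay on a cell-free system (plasma, Oryctolagus cuniculus) for inhibition of platelet-activating factor acetylhydrolase (Homo sapiens), tested at 100 nM; on this read-out lower numbers stand for less inhibition and higher numbers for more inhibition at the one concentration tested (going by the name of the read-out):
Compound 1, `CCCCCCCCCCCCN(C)C(=O)Cn1cc(Cc2cnc(=O)n(C)c2)c(=O)nc1SCc1ccc(F)cc1`, gives 32%.
Compound 2, `CCCCCCCCCCCCN(C)C(=O)Cn1cc(Cc2cnc(=O)n(CC(=O)OCC)c2)c(=O)nc1SCc1ccc(F)cc1`, gives 15%.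
Compound 3, `CCCCCCCCCCCCN(C)C(=O)Cn1cc(Cc2cnc(=O)n(CC(=O)NCCO)c2)c(=O)nc1SCc1ccc(F)cc1`, gives 37%.

Compound 3 holds the highest of the three numbers, though compound 1 lies within the scatter of it (a number 5 percentage points higher from compound 1 to compound 3 (within the scatter)), while compound 2 sits clearly lower (a number 22 percentage points higher from compound 2 to compound 3 (beyond the scatter)). Compound 4, `CCCCCCCCCCCCN(C)C(=O)Cn1cc(Cc2cnc(=O)n(CC(=O)N3CCNC(=O)C3)c2)c(=O)nc1SCc1ccc(F)cc1`, differs from compound 3 only at the carbonyl carbon: 3-oxopiperazin-1-yl in place of (2-hydroxyethyl)amino on a carbonyl carbon. Going by the values given here, the one earlier step at that same carbonyl carbon, a number 22 percentage points higher from compound 2 to compound 3 (beyond the scatter), was a modest rise when ethoxy gave way to (2-hydroxyethyl)amino; the remaining step, a number 17 percentage points lower from compound 1 to compound 2 (beyond the scatter), was also modest. With an amide kept in place, the expected step is a number 7 percentage points lower from compound 3 to compound 4 (within the scatter), small and possibly within the scatter. Compound 4 is therefore estimated at 30%, with a range from 15% to 48%.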

Compound 4, a percentage reported as inhibition, at one concentration (the size of the read-out at that concentration, not a potency): 49%
Beside the measured number, compound 4's estimate is 19 percentage points below it; the measured number lies above the stated range.
By their numbers in this assay, from the lowest: compound 2; then compounds 1 and 3 (each within the scatter of the next); then compound 4.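

On this carbonyl carbon, the choice of amide now matters in this assay: 3-oxopiperazin-1-yl outdoes (2-hydroxyethyl)amino (a number 12 percentage points higher from compound 3 to compound 4 (beyond the scatter)) and stands further from ethoxy (a number 34 percentage points higher from compound 2 to compound 4 (beyond the scatter)). Unlike (2-hydroxyethyl)carbamoyl, (3-oxopiperazin-1-yl)carbonyl also clears the scatter when set against hydrogen on the chain carbon (a number 17 percentage points higher from compound 1 to compound 4 (beyond the scatter)). Nothing available explains this rise. Open, on these data alone, is whether the ring or its carbonyl matters more, as a piperazin-1-yl or morpholin-4-yl group on the same carbonyl carbon could show.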